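Aryl Swap on a Triazole-Linked Bicyclic Lactam Core

A few compounds are considered here, and "the series" means these few. Any claim that something is new, unique, unknown or untested is made for them only; others in the source may bear on it.

Measured compounds:
compound 1, `CC1(C)[C@H]2CC[C@]1(C)N(Cc1cn(-c3cccc(Cl)c3)nn1)C(=O)C2`: 50 nM
compound 2, `CC1(C)[C@H]2CC[C@]1(C)N(Cc1cn(-c3cccc(O)c3)nn1)C(=O)C2`: 370 nM

In a functional assay on OVCAR-3 cells (Homo sapiens) for inhibition, read by MTT assay, with a stated time of 24 h (a lower number here means a stronger inhibitor, a higher number a weaker inhibitor), compound 1 gives 50 nM, the lowest of the two numbers recorded; its nearest neighbour is compound 2, which in this assay gives 370 nM. Within the data shown here, the one measured step, hydroxy in place of chloro on an aromatic carbon, is a 7.4-fold higher number from compound 1 to compound 2 (0.87 log units; beyond the scatter).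

Compound 3, `COc1ccc(-n2cc(CN3C(=O)C[C@@H]4CC[C@@]3(C)C4(C)C)nn2)cc1`, has not yet been tested. It differs from compound 1 in a single place: 4-methoxyphenyl in place of 3-chlorophenyl on an aromatic nitrogen. The step from compound 1 to compound 2 bears on this only loosely, since it exchanges the chloro for an oxygen-bearing group without moving it, whereas here the whole aryl group is replaced. That step was modest but beyond the scatter, so an oxygen-bearing aryl group in place of the chlorophenyl is expected to give a higher number than compound 1, likely of similar or slightly smaller size. The expected step is a 3.2-fold higher number from compound 1 to compound 3 (0.51 log units; beyond the scatter). Compound 3 is therefore estimated at 160 nM, with a range from 50 nM to 500 nM.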

Compound 3, half-maximal inhibitory concentration: 250 nM
Compound 3: middle estimate off by 1.6-fold (0.19 log units), on the low side, and the stated range covers the measured number.
By their numbers in this assay, from the lowest: compound 1; then compounds 3 and 2 (each within the scatter of the next).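

In this assay the 3-chlorophenyl group on the aromatic nitrogen proves better than a second oxygen-bearing aryl group as well, not only better than the 3-hydroxyphenyl group of compound 2 (a 5.0-fold higher number from compound 1 to compound 3 (0.70 log units; beyond the scatter)), so compound 1 now stands as the strongest of the three. The two oxygen-bearing groups cannot be told apart in this assay (a 1.5-fold lower number from compound 2 to compound 3 (0.17 log units; within the scatter)), even though 3-hydroxyphenyl and 4-methoxyphenyl differ both in the group carried and in where it sits on the phenyl ring. No evidence at hand accounts for why compound 1 stands apart from the other two.

Because chloro and methoxy sit at different places on the phenyl ring in compound 1 and compound 3, the compounds shown do not separate the effect of the group from that of its place, as a 4-chlorophenyl or a 3-methoxyphenyl group would. Also open, as far as these compounds go, is whether bromo or trifluoromethyl could stand in for the chloro, and how an amine or a carboxylic acid on the phenyl ring would fare.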